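Fluoro in Place of Hydrogen on Two Related Cores

The source may report more compounds than this note shows. Statements on the series, on what has been measured and on what is new or still open speak of the compounds shown alone.

Measured compounds:
compound 1, `O=C1CC(c2ccccc2)n2ncnc2N1`: 51.9 mg/kg
compound 2, `O=C1CC(c2ccccc2F)n2ncnc2N1`: 31.7 mg/kg
compound 3, `O=C1CC(c2ccccc2)n2nccc2N1`: 47.3 mg/kg

In a functional assay on the whole organism (strain Kunming) with Mus musculus as the target (on this read-out higher numbers stand for an effect only at larger amounts of compound and lower numbers for an effect already at smaller amounts), compound 1 gives 51.9 mg/kg and compound 2 gives 31.7 mg/kg. The two differ by one change, (fluoro in place of hydrogen on an aromatic carbon), and the step is a 1.6-fold lower number from compound 1 to compound 2 (0.21 log units; within the scatter). Compound 3 carries a different core; how its core differs from that of compound 1 is not broken down here. In this assay compound 3 gives 47.3 mg/kg, a number close to that of compound 1.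

Compound 4, `O=C1CC(c2ccccc2F)n2nccc2N1`, has not yet been measured. It stands to compound 3 as compound 2 stands to compound 1: the change is fluoro in place of hydrogen on an aromatic carbon, at the same kind of place as before. Since the earlier step was a 1.6-fold lower number from compound 1 to compound 2 (0.21 log units; within the scatter), a step of about the same size is expected here, a 1.5-fold lower number from compound 3 to compound 4 (0.18 log units; within the scatter), resting on the value of compound 3, 47.3 mg/kg. Compound 4 is therefore estimated at 31 mg/kg, with a range from 18 mg/kg to 52 mg/kg.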

Compound 4, dose for half-maximal effect: 47.3 mg/kg
Estimate against measurement, compound 4: 1.5-fold (0.18 log units) below; the measured number falls inside the stated range.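

In this assay, fluoro in place of hydrogen on an aromatic carbon, on the core of compound 3, gives no change at the digits printed from compound 3 to compound 4 (within the scatter). Set beside the same change on the core of compound 1, this step shows no difference that stands out from the scatter: the same change on two cores in this assay, a 1.6-fold lower number (0.21 log units; within the scatter) from compound 1 to compound 2 and no change at the digits printed (within the scatter) from compound 3 to compound 4, 1.6-fold (0.21 log units) apart, within the scatter of two such steps. The two cores are thus consistent with one shared step, but neither step lies beyond the scatter, so the pair does not establish that fluoro moves the number on either core, nor that the steps are truly equal, and it says nothing about any core other than these two.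

The compounds shown carry only hydrogen or fluoro at this place on the six-membered aromatic ring. As far as these compounds go, it remains open whether a different group there, such as chloro, methoxy, trifluoromethyl or an amine, would give a step beyond the scatter, and whether such a step would carry from one core to the other.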